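A Bromine for a Fluorine on Weakly Cytotoxic Compounds

The compounds below may be only part of what the source reports. "The series", "measured", "known", "first", "only" and "open" are said of these compounds alone.

Compound 1 `Fc1cccc(-c2nc(Nc3ccccc3)c3ccccc3n2)c1` yields no number in a functional assay on MDA-MB-231 cells (Homo sapiens) for cytotoxicity, read by MTT assay, with a stated time of 48 h; on this read-out higher numbers stand for weaker inhibition and lower numbers for stronger inhibition: its value there, > 50000 nM, is a limit of the assay. Going by the values given here, compound 2 `Fc1cccc(Nc2nc(-c3cccc(F)c3)nc3ccc(F)cc23)c1` is the only one with a measured number, giving 47600 nM in this assay. Compound 3 `Fc1cccc(-c2nc(Nc3cccc(Br)c3)c3cc(F)ccc3n2)c1` differs from compound 2 by bromo in place of fluoro on an aromatic carbon. Among the compounds with values here, no step between measured compounds is available, so any shift from compound 2 to compound 3 is expected to be small, hardly beyond the scatter. Compound 3 is expected to give 35000 nM in this assay, within a range from 12000 nM to 100000 nM. This amounts to an expected step of a 1.4-fold lower number from compound 2 to compound 3 (0.13 log units; within the scatter).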

Compound 3, half-maximal inhibitory concentration: > 50000 nM
Compound 3 was reported as a limit; the forecaster's own chance of this, stated with the estimate: 40%; at least 1.4-fold (0.15 log units) between middle value and limit.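

Bromo in place of fluoro at this position, meta to a large group, brings no sign of stronger inhibition in this assay: the change gives an at least 1.0-fold higher number from compound 2 to compound 3 (0.02 log units; that floor lies within the scatter). Compound 3 stands as a limit, and only that floor is known. The true size of the step cannot be read, and the position stays at the edge of what the assay reports: the limit of > 50000 nM in this assay, at which 2 of the 3 values shown sit.

On these data alone, how an amine or a carboxylic acid in place of the halogen at this position would read remains open. As far as these compounds go, whether any group here can bring the number well down also stays open.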